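The source may hold more compounds than are shown below. What is called first, only, known or untested is meant among the compounds shown, and "the series" means these compounds.

Working notes on the series.

The shared core is held constant across the set; compound 1 `CCc1nc2c(C)cc(-c3ccc(CN4CCC(O)CC4)cc3)cn2c1NC(=O)OCc1cc(Cl)cc(Cl)c1` carries a hydroxypiperidinyl group on the saturated chain carbon bound to the aromatic carbon, compound 2 `CCc1nc2c(C)cc(-c3ccc(CN4CCC[C@H]4CO)cc3)cn2c1NC(=O)OCc1cc(Cl)cc(Cl)c1` a pyrrolidinylmethanol group at that place, compound 3 `CCc1nc2c(C)cc(-c3ccc(CN4CCN(C)CC4)cc3)cn2c1NC(=O)OCc1cc(Cl)cc(Cl)c1` a 4-methylpiperazin-1-yl group, and the unmeasured compound 4 `CCc1nc2c(C)cc(-c3ccc(CN4CCC(C)CC4)cc3)cn2c1NC(=O)OCc1cc(Cl)cc(Cl)c1` a 4-methylpiperidin-1-yl group. In a functional assay on MDA-MB-231 cells (Homo sapiens) for inhibition, read by MTT assay, with a stated time of 72 h (on this read-out lower numbers stand for stronger inhibition and higher numbers for weaker inhibition), compound 1 gives 1580 nM. In this assay, among the compounds with values here, compound 2 gives "nd" (no result reported) and compound 3 gives "nd" (no result reported), so neither has a number reported, compound 3 stands without a value of its own, and no step between measured compounds can be read from this set.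

The change from compound 3 to compound 4 is 4-methylpiperidin-1-yl in place of 4-methylpiperazin-1-yl on a saturated chain carbon bound to an aromatic carbon.

Within the data shown here, with no measured step available, the expectation for compound 4 rests on compound 1 alone, whose value 1580 nM is the only anchor; no direction can be assigned, and a result within the scatter of that anchor is expected. Compound 4 is therefore estimated at 1500 nM in this assay, within a range of 400 nM to 6000 nM.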

Compound 4, half-maximal inhibitory concentration: 5830 nM
Compound 4: middle estimate off by 3.9-fold (0.59 log units), on the low side; low and high end bracket the measured number.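

In this assay the series now has its first readable step: methyl in place of hydroxy on a saturated ring carbon gives a 3.7-fold higher number from compound 1 to compound 4 (0.57 log units; beyond the scatter) and so shows that the read-out responds to the group held at this ring carbon, with the hydroxy group on the side of the lower number. The change from 4-methylpiperazin-1-yl to 4-methylpiperidin-1-yl itself cannot be read, and neither can any step to compound 2, since compound 2 and compound 3 carry no number. Nothing available gives a reason for the size or direction of this step.

Going by these compounds, whether an amine, a carboxylic acid or a fluorine on that saturated ring carbon would sit with the hydroxy group or the methyl group remains open. Also open, on these data alone, is how an unsubstituted piperidin-1-yl group would compare with compound 1 and compound 4.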